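Adding a Methyl Group: Expected Effect on Cell Toxicity

The source may hold more compounds than are shown below. What is called first, only, known or untested is meant among the compounds shown, and "the series" means these compounds.

Compound 1 `COc1nc(C)nc(/N=C/c2ccc(Br)cc2)n1` and compound 2 `COc1nc(C)nc(/N=C(\C)c2ccccc2)n1` share one core. In an ADME assay on Vero cells (Chlorocebus sabaeus) for cytotoxicity, read by MTT assay, with a stated time of 72 h (on this read-out higher numbers stand for weaker inhibition and lower numbers for stronger inhibition), compound 1 gives > 50 ug/mL, which is a limit of the assay and not a number. For compound 2, this assay reports "not determined" (no result reported), so compound 2 stands nowhere on the numbers shown. Compound 3 `COc1nc(C)nc(/N=C(\C)c2ccc(C)cc2)n1` differs from compound 2 by methyl in place of hydrogen on an aromatic carbon. Among the compounds with values here, with no step between measured compounds known, no shift in this assay beyond the usual scatter is expected from this change. Because compound 1 sits at the limit of > 50 ug/mL in this assay, at which 1 of the 2 values shown sits, compound 3 is expected to give about 50 ug/mL, likely between 20 ug/mL and 120 ug/mL, and quite possibly again only a limit.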

Compound 3, half-maximal inhibitory concentration: > 50 ug/mL
Compound 3 ended at the assay's limit; the forecaster's own chance of this, stated with the estimate: 70%; the middle value sits exactly at the limit.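

No step can be read between compound 2 and compound 3 from these results, and the result for compound 3 is only a limit of the assay. Left open is whether methyl in place of hydrogen shifts the reading at all in this assay.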